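From dichlorophenyl to a hydroxy-bearing ring: estimating compound 4

This account rests on a few compounds, and the source may have more. Where it says the series, first, only, none or still open, it means among the compounds named here.

Three compounds share one core and differ in a single ring group. In a functional assay on SW-620 cells (Homo sapiens) for cytotoxicity, read by MTT assay, with a stated time of 72 h (on this read-out lower numbers stand for stronger inhibition and higher numbers for weaker inhibition), compound 1 `COc1cccc(/C=C2\CCC/C(=C\c3cccc(O)c3)C2=O)c1OC` gives 6400 nM, compound 2 `COc1cccc(/C=C2\CCC/C(=C\c3cccc(Cl)c3Cl)C2=O)c1OC` gives 16300 nM, and compound 3 `COc1cccc(/C=C2\CCC/C(=C\c3ccc(Cl)cc3Cl)C2=O)c1OC` gives 16300 nM. Compound 3 therefore stands level with compound 2, and together they hold the highest of the three numbers.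

The next compound, compound 4 `COc1cc(/C=C2\CCC/C(=C\c3cccc(OC)c3OC)C2=O)ccc1O`, keeps the core and changes one group, on a double-bonded chain carbon bound to a double-bonded ring carbon: 4-hydroxy-3-methoxyphenyl in place of 2,4-dichlorophenyl on a double-bonded chain carbon bound to a double-bonded ring carbon.

Two kinds of measured step bear on this swap. Replacing 3-hydroxyphenyl with a dichlorophenyl group gave a 2.5-fold higher number from compound 1 to compound 2 (0.41 log units; beyond the scatter) and likewise a 2.5-fold higher number from compound 1 to compound 3 (0.41 log units; beyond the scatter), both modest. Moving a chlorine gave no change at the digits printed from compound 2 to compound 3 (within the scatter), so the exact chlorine pattern shows no effect here. The entering group carries a hydroxy group, as the matching group of compound 1 does, so a partial or full return towards 6400 nM seems reasonable. Among the compounds with values here, no measured compound has a methoxy group at this place, and only one has a hydroxy group there, so the evidence is thin.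

The expected change is a 2.2-fold lower number from compound 3 to compound 4 (0.34 log units; beyond the scatter), a modest move to a lower number. In this assay, compound 4 is estimated at 7500 nM, with an expected range of 3000 nM to 17000 nM.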

Compound 4, half-maximal inhibitory concentration: 8600 nM
Compound 4: the middle estimate sits 1.1-fold (0.06 log units) below what was measured; low and high end bracket the measured number.
By their numbers in this assay, from the lowest: compounds 1, 4, 2 and 3 (each within the scatter of the next, the first and the last beyond it).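

Compound 4 is the first compound shown with a methoxy group at this place, and its ring cannot be told apart from any of the earlier ones: the reading is a 1.9-fold lower number from compound 3 to compound 4 (0.28 log units; within the scatter) and also a 1.9-fold lower number from compound 2 to compound 4 (0.28 log units; within the scatter) while the comparison with the hydroxy ring gives a 1.3-fold higher number from compound 1 to compound 4 (0.13 log units; within the scatter) as its result. Compound 1 and the two dichlorophenyl compounds do differ beyond the scatter, yet compound 4 sits within the scatter of all three, so the earlier split into a hydroxy level and a dichloro level does not extend to a clear third level, and 4-hydroxy-3-methoxyphenyl is accepted at this place without any clear gain or loss. Nothing supplied explains why these rings read as they do and the numbers alone cannot say whether the hydroxy group or the methoxy group of compound 4 counts for more.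

From the compounds shown here alone, it remains open what a ring with only a methoxy group, or a plain phenyl ring, would give on this same core. Also open, going by these compounds, is how a ring carrying an amine or a carboxylic acid would behave at this place.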